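From ethoxycarbonyl to methylamino at one ring carbon

The source may hold more compounds than are shown below. What is called first, only, known or untested is meant among the compounds shown, and "the series" means these compounds.

In a functional assay on cells (Homo sapiens), read by thymidine incorporation (on this read-out lower numbers stand for stronger inhibition and higher numbers for weaker inhibition), compound 1 `Cc1cc(NCc2cccnc2)n2ncc(Br)c2n1` gives 1800 nM and compound 2 `Brc1cnn2c(NCc3cccnc3)cc(C3CC3)nc12` gives 1500 nM, while compound 3 `CCOC(=O)c1cc(NCc2cccnc2)n2ncc(Br)c2n1` gives 2900 nM, which lies within the scatter of both. Compound 4 `CNc1cc(NCc2cccnc2)n2ncc(Br)c2n1` carries methylamino in place of ethoxycarbonyl on an aromatic carbon when set against compound 3. Going by the values given here, three measured steps bear on this carbon, namely a 1.2-fold lower number from compound 1 to compound 2 (0.08 log units; within the scatter), a 1.6-fold higher number from compound 1 to compound 3 (0.21 log units; within the scatter) and a 1.9-fold higher number from compound 2 to compound 3 (0.29 log units; within the scatter), and all of them are small. Among the compounds with values here, no measured compound carries methylamino there, so the range stays wide. No step beyond the scatter is expected, and the estimated change is a 1.5-fold lower number from compound 3 to compound 4 (0.16 log units; within the scatter) in this assay. Compound 4 is estimated at 2000 nM, with an expected range of 700 nM to 5500 nM.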

Compound 4, half-maximal inhibitory concentration: 1200 nM
Estimate against measurement, compound 4: 1.7-fold (0.22 log units) above, within the range that was stated.
By their numbers in this assay, from the lowest: compounds 4, 2, 1 and 3 (each within the scatter of the next, the first and the last beyond it).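

In this assay, going by these compounds alone, methylamino in place of ethoxycarbonyl gives the first step at this aromatic carbon that lies beyond the scatter (a 2.4-fold lower number from compound 3 to compound 4 (0.38 log units; beyond the scatter)). Against the other two groups, methylamino stays within the scatter (a 1.3-fold lower number from compound 2 to compound 4 (0.10 log units; within the scatter); a 1.5-fold lower number from compound 1 to compound 4 (0.18 log units; within the scatter)), so it separates only from ethoxycarbonyl, and the span across these four groups remains narrow. Nothing measured here accounts for that step. Open, going by these compounds, is whether the hydrogen on the methylamino nitrogen matters, which a dimethylamino group at this carbon would test. On these data alone, a carboxylic acid or a longer alkylamino chain there also remains open.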